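Trimethoxyphenyl on the Ketone: Outlook for Compound 4

A few compounds are considered here, and "the series" means these few. Any claim that something is new, unique, unknown or untested is made for them only; others in the source may bear on it.

Of the compounds shown here, three sharing one core have been tested in a functional assay on PC-3 cells (Homo sapiens) for cytotoxicity, read by MTT assay, with a stated time of 48 h; a higher number here means a weaker inhibitor, a lower number a stronger inhibitor. Compound 1 `COc1cc(C(=O)C2Sc3nnc(-c4cc(OC)c(OC)c(OC)c4)n3NC2c2ccco2)cc(OC)c1OC` gives 52200 nM. Compound 2 `COc1cc(-c2nnc3n2NC(c2ccco2)C(C(=O)c2ccccc2F)S3)cc(OC)c1OC` reaches only a limit of the assay, > 100000 nM, so no number is known for it. Compound 3 `COc1cc(-c2nnc3n2NC(c2cccs2)C(C(=O)c2ccccc2)S3)cc(OC)c1OC` gives 86300 nM; of the two real numbers this is the higher one, yet its distance from compound 1 is within the scatter, so no order between compound 1 and compound 3 can be read from the data.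

Compound 4 `COc1cc(C(=O)C2Sc3nnc(-c4cc(OC)c(OC)c(OC)c4)n3NC2c2cccs2)cc(OC)c1OC` is not yet measured. It differs from compound 3 in one place: 3,4,5-trimethoxyphenyl in place of phenyl on a carbonyl carbon. Among the compounds with values here, one measured step touches the same position, running the other way: an at least 1.9-fold higher number from compound 1 to compound 2 (0.28 log units; that floor lies within the scatter). That step is known only as a floor because the limit of > 100000 nM in this assay, at which 1 of the 3 values shown sits, is where compound 2 sits. Compound 1 already carries the 3,4,5-trimethoxyphenyl on the carbonyl carbon and gives 52200 nM, which is close to compound 3.

Taken together, a small move toward a lower number is expected, not clearly beyond the scatter, giving a 1.7-fold lower number from compound 3 to compound 4 (0.24 log units; within the scatter). Compound 4 is therefore estimated at 50000 nM, with a range from 20000 nM to 120000 nM.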

Compound 4, half-maximal inhibitory concentration: > 100000 nM
Compound 4 was reported as a limit (the forecaster's own chance of this, stated with the estimate: 20%); at least 2.0-fold (0.30 log units) between middle value and limit.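

Compound 4 gives > 100000 nM, which is a limit of the assay and not a number, so carrying the 3,4,5-trimethoxyphenyl on the carbonyl carbon does not by itself keep a compound of this series inside the measurable range. Putting this group in place of phenyl gives an at least 1.1-fold higher number from compound 3 to compound 4 (0.06 log units; that floor lies within the scatter), and the first change shown on the saturated ring carbon, thiophen-2-yl in place of furan-2-yl, gives an at least 1.9-fold higher number from compound 1 to compound 4 (0.28 log units; that floor lies within the scatter), so neither change can be said to raise the number beyond the usual scatter. The true size of both steps stays unknown because each one ends at the same ceiling: the limit of > 100000 nM in this assay, at which 2 of the 4 values shown sit.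

The compounds shown leave open whether any group on the carbonyl carbon can bring the number clearly down, for instance an amine or a carboxylic acid in place of the 3,4,5-trimethoxyphenyl. They also leave open how furan-2-yl and thiophen-2-yl compare when phenyl sits on the carbonyl carbon, since only one of those two combinations appears here.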